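A few compounds are considered here, and "the series" means these few. Any claim that something is new, unique, unknown or untested is made for them only; others in the source may bear on it.

Measured compounds in an assay on HEK293 cells for displacement of a labelled ligand from corticotropin-releasing factor receptor 1 (Homo sapiens); a lower number here means a stronger inhibitor, a higher number a weaker inhibitor:

- compound 1 `CCCN(C)c1cc(C)nc2c(-c3ccc(Cl)cc3Cl)nn(C)c12` gives 24 nM
- compound 2 `CCCCN(c1cc(C)nc2c(-c3ccc(Cl)cc3Cl)nn(C)c12)C(CC)CC` gives 7 nM
- compound 3 `CCCCN(CCCC)c1cc(C)nc2c(-c3c(C)cc(C)cc3Cl)nn(C)c12` gives 2.1 nM

Of the three numbers, compound 2 holds the second highest. Its nearest neighbour is compound 3, whose number is lower by a gap beyond the scatter; its furthest is compound 1, whose number is higher, also by a gap beyond the scatter. None of the three pairs differ in only one place, so no single change can be read off directly from the measured set; the three compounds differ in the substituents on the amine nitrogen and on the pendant aryl ring at once.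

Compound 4 `CCCCN(Cc1ccncc1)c1cc(C)nc2c(-c3ccc(Cl)cc3Cl)nn(C)c12` is not yet measured. It differs from compound 2 in one place: (pyridin-4-yl)methyl in place of pentan-3-yl on a nitrogen on an aromatic ring. The remaining butyl on that nitrogen, the shared core and the dichlorophenyl group are unchanged.

Among the measured compounds shown here, the measured set gives no step to guide this change. On the evidence available, a moderate rise in the number is expected, likely beyond the scatter but not large. For compound 4 the expected value in this assay is 30 nM, with a range from 8 nM to 120 nM; the estimated step of a 4.3-fold higher number from compound 2 to compound 4 (0.63 log units; beyond the scatter) is towards a weaker inhibitor.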

Compound 4, inhibition constant: 68 nM
Compound 4: middle estimate off by 2.3-fold (0.36 log units), on the low side; measured number inside the range.
By their numbers in this assay, from the lowest: compound 3; then compound 2; then compound 1; then compound 4.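

In this assay, among the compounds shown here, the change from pentan-3-yl to (pyridin-4-yl)methyl on this nitrogen gives a 9.7-fold higher number from compound 2 to compound 4 (0.99 log units; beyond the scatter) and is the first change that can be read in one place. With the butyl, the shared core and the dichlorophenyl group unchanged, the number responds to this substituent alone, moving towards a weaker inhibitor as a chain with no ring and no hydrogen-bond acceptor gives way to a six-membered aromatic ring with one hetero atom and one hydrogen-bond acceptor. No measurement at hand accounts for the direction or size of this step.

Still open, on these data alone, is which part of the entering group carries the step, since the ring and its nitrogen change together here, and a plain benzyl group on the same nitrogen would separate the two. Also open, as far as these compounds go, is how this nitrogen responds to a saturated group such as cyclopropylmethyl, or to a longer chain ending in a morpholine, and whether the step keeps its size with the chloro-dimethylphenyl group of compound 3.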